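The source may report more compounds than this note shows. Statements on the series, on what has been measured and on what is new or still open speak of the compounds shown alone.

Measured compounds and their readings:

Compound 1, `CN(Cc1cccnc1)C(=S)SCc1ccc(C(=O)Nc2ccccc2N)cc1`, gives 85.5% in a functional assay on MGC-803 cells (Homo sapiens) for antiproliferative activity, read by CCK-8 assay, with a stated time of 72 h, tested at 8 uM; a lower number here means a weaker effect, a higher number a stronger effect of the compound at the concentration tested.
Compound 2, `CN(Cc1ccncc1)C(=S)SCc1ccc(C(=O)Nc2ccccc2N)cc1`, gives 83.2% in this assay.
Compound 3, `Nc1ccccc1NC(=O)c1ccc(CSC(=S)N2CCN(c3ccc(F)cc3)CC2)cc1`, gives 48.7% in this assay.

Compound 3 stands lowest of the three: compound 1 and compound 2 both sit higher by gaps that lie beyond the usual scatter, so its weaker effect in this assay is a real difference and not noise.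

Compound 4, `N#Cc1ccc(N2CCN(C(=S)SCc3ccc(C(=O)Nc4ccccc4N)cc3)CC2)cc1`, has not yet been tested. It differs from compound 3 in one place only: cyano in place of fluoro on an aromatic carbon.

Among the compounds with values here, the only measured step, a number 2.3 percentage points lower from compound 1 to compound 2 (within the scatter), concerns a change at a different part of the molecule, the saturated chain carbon bound to an amide-type nitrogen, and so says nothing about swapping groups on the aromatic ring that carries the fluoro. Within the data shown here, no pair among the measured compounds tests a fluoro against a cyano anywhere. With no guide from the data, the expected change in this assay is none beyond the scatter, and the estimate for compound 4 is 50%, within a broad range from 30% to 70%, which corresponds to an expected step of a number 1.3 percentage points higher from compound 3 to compound 4 (within the scatter).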

Compound 4, a percentage reported as inhibition, at one concentration (the size of the read-out at that concentration, not a potency): 37.6%
Compound 4: middle estimate off by 12.4 percentage points, on the high side; measured number inside the range.
By their numbers in this assay, from the lowest: compound 4; then compound 3; then compounds 2 and 1 (each within the scatter of the next).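

Within the data shown here, replacing 4-fluorophenyl with 4-cyanophenyl is the first change tested on this aromatic ring, and in this assay it gives a number 11.1 percentage points lower from compound 3 to compound 4 (beyond the scatter). The position para to a large group is therefore not a silent one: exchanging a single fluorine for the two-atom cyano group lowers the reading. The step lies beyond the usual scatter of repeat measurements, although it is only modest. No measurement shown here bears on why the cyano compound reads lower, so the step stands as an observation without an explanation.

Going by these compounds, two groups at this carbon give one step and not a trend, so it remains open how the reading would move with a hydrogen, a methoxy group, an amine or a carboxylic acid in the same place. Also open, on these data alone, is whether the cyano-for-fluoro swap would lower the reading in the same way on another core, or in other cells, since this step comes from one pair of compounds in one cell line at one concentration.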